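This account rests on a few compounds, and the source may have more. Where it says the series, first, only, none or still open, it means among the compounds named here.

Compound 1, `Fc1cccc(Nc2nccc(-c3ccccn3)n2)c1`: 1000 nM in a functional assay for inhibition, with Homo sapiens as the target; a lower number here means a stronger inhibitor, a higher number a weaker inhibitor
Compound 2, `CC(=O)Nc1cccc(Nc2nccc(-c3ccccn3)n2)c1`: 300 nM in this assay
Compound 3, `Fc1cccc(Nc2nccc(-c3ccncc3)n2)c1`: 700 nM in this assay

Compound 4, `CC(=O)Nc1cccc(Nc2nccc(-c3ccncc3)n2)c1`, has not yet been measured in this assay. It differs from compound 3 by a single change, (acetamido in place of fluoro on an aromatic carbon). The same change is already measured once, from compound 1 to compound 2, where acetamido in place of fluoro on an aromatic carbon gave a 3.3-fold lower number from compound 1 to compound 2 (0.52 log units; beyond the scatter). The two cores differ by pyridin-4-yl in place of pyridin-2-yl on an aromatic carbon, a change that gave a 1.4-fold lower number from compound 1 to compound 3 (0.15 log units; within the scatter). The surroundings of the change are the same in both pairs, so it is the same change on a slightly different core. For compound 4 a step of a 2.8-fold lower number from compound 3 to compound 4 (0.45 log units; beyond the scatter) is expected, close to the earlier one, resting on a 3.3-fold lower number from compound 1 to compound 2 (0.52 log units; beyond the scatter) for compound 2. Compound 4 is therefore estimated at 250 nM, between 100 nM and 600 nM.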

Compound 4, half-maximal inhibitory concentration: 2700 nM
Estimate against measurement, compound 4: 11-fold (1.03 log units) below; the measured number lies above the stated range.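

In this assay, the swap of fluoro for acetamido does not carry from one core to the other: where it gave a stronger inhibitor on the core of compound 1, here it gives a 3.9-fold higher number from compound 3 to compound 4 (0.59 log units; beyond the scatter), a reversal of direction: the same change on two cores in this assay, a 3.3-fold lower number (0.52 log units; beyond the scatter) from compound 1 to compound 2 and a 3.9-fold higher number (0.59 log units; beyond the scatter) from compound 3 to compound 4, 13-fold (1.11 log units) apart, beyond the scatter of two such steps. Read the other way, pyridin-4-yl in place of pyridin-2-yl gives a 9.0-fold higher number from compound 2 to compound 4 (0.95 log units; beyond the scatter), so the effects of the two changes do not simply add: the same change on two cores in this assay, a 1.4-fold lower number (0.15 log units; within the scatter) from compound 1 to compound 3 and a 9.0-fold higher number (0.95 log units; beyond the scatter) from compound 2 to compound 4, 13-fold (1.11 log units) apart, beyond the scatter of two such steps. This shows that the outcome of each change depends on the other in these four compounds, but it does not show why, or whether this holds beyond them.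

On these data alone, it remains open how an amine or a carboxylic acid in place of fluoro would behave on each core. The same question stands for pyridin-3-yl as the ring that varies.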